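The source may report more compounds than this note shows. Statements on the series, on what has been measured and on what is new or still open speak of the compounds shown alone.

Of the compounds shown here, two that share one core have been tested in a functional assay on HepG2 cells (Homo sapiens) for antiproliferative activity, read by MTT assay, with a stated time of 24 h; a higher number here means a weaker inhibitor, a lower number a stronger inhibitor. Compound 1 `C=CCc1cc(-c2cccc([N+](=O)[O-])c2)ccc1O` gives > 100000 nM, which is a limit and not a number. Compound 2 `C=CCc1cc(-c2cccc(SC)c2)ccc1O` gives > 100000 nM, which is also a limit. Compound 2 therefore stands at the limit of > 100000 nM in this assay, at which 2 of the 2 values shown sit, with no exact value. Among the measured compounds shown here, the only measured change is a step that the two limits leave unreadable from compound 1 to compound 2, so it offers no size to carry forward. Compound 3 `C=CCc1cc(-c2cccc(OC)c2)ccc1O` differs from compound 2 by one change, methoxy in place of methylsulfanyl on an aromatic carbon, meta to a large group. With both measured compounds at the limit, no step beyond the scatter is expected in this assay, and no direction can be favoured. The estimated change is a number no higher from compound 2 to compound 3 (the limit leaves the size open). Compound 3 is estimated at 100000 nM, with an expected range from 30000 nM to 300000 nM.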

Compound 3, half-maximal inhibitory concentration: > 100000 nM
Compound 3: no number, only a limit; the forecaster's own chance of this, stated with the estimate: 75%; the middle value lies on the limit itself.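

Among the compounds shown here, compound 3, like compound 1 and compound 2, gives a limit and not a number, so no step among the three can be read: the limit of > 100000 nM in this assay, at which 3 of the 3 values shown sit. Still open, on these data alone, is the true size of each value, and whether exchanging these groups changes it at all.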